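A few compounds are considered here, and "the series" means these few. Any claim that something is new, unique, unknown or untested is made for them only; others in the source may bear on it.

Compound 1 `O=C(CCCCC(S)CCS)Nc1ccccc1` is one of three analogues of a shared core that have been tested in a functional assay on HO8910 cells (Homo sapiens) for inhibition, read by MTT assay, with a stated time of 24 h, tested at 100 ug/mL; on this read-out lower numbers stand for less inhibition of growth and higher numbers for more inhibition of growth at the one concentration tested. Compound 1 gives 13.7%, the lowest of the three numbers. Compound 2 `O=C(CCCCC(S)CCS)Nc1ccc(Cl)cc1`, with chloro in place of hydrogen on an aromatic carbon, gives 21.3%, and the step is a number 7.6 percentage points higher from compound 1 to compound 2 (within the scatter). Compound 3 `O=C(CCCCC(S)CCS)Nc1ccc(OC(F)(F)F)cc1`, bearing trifluoromethoxy in place of hydrogen on an aromatic carbon, gives 66.8%; the step is a number 53.1 percentage points higher from compound 1 to compound 3 (beyond the scatter), and from the chloro analogue it is a number 45.5 percentage points higher from compound 2 to compound 3 (beyond the scatter).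

Compound 4 `Cc1cccc(NC(=O)CCCCC(S)CCS)c1` has not yet been measured in this assay. It differs from compound 1 by methyl in place of hydrogen on an aromatic carbon, the methyl sitting meta to a large group. Among the measured compounds shown here, no measured step replaces hydrogen with methyl, so the nearest guide is the chloro step a number 7.6 percentage points higher from compound 1 to compound 2 (within the scatter), which stayed within the scatter, whereas the large gain appeared only with trifluoromethoxy in compound 3 a number 53.1 percentage points higher from compound 1 to compound 3 (beyond the scatter). A modest change, if any, is therefore expected in this assay. The expected step from compound 1 to compound 4 is a number 6.3 percentage points higher from compound 1 to compound 4 (within the scatter). Compound 4 is estimated at 20%, within a range of 5% to 40%.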

Compound 4, percent growth inhibition at one concentration: "not active" (no number reported)
Compound 4: no number reported; the estimate stays without a comparison.
By their numbers in this assay, from the lowest: compounds 1 and 2 (each within the scatter of the next); then compound 3.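

Among the compounds shown here, compound 4 is reported as "not active" in this assay without a number, so no step from compound 1 to compound 4 can be read. The compounds shown leave open how a methyl group compares with chloro or trifluoromethoxy on this read-out. Nothing shown accounts for this result.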